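Acyl variation on the shared core: ethyl to phenyl

The source may report more compounds than this note shows. Statements on the series, on what has been measured and on what is new or still open speak of the compounds shown alone.

Measured compounds in a functional assay on MDA-MB-231 cells (Homo sapiens) for cytotoxicity, read by sulforhodamine B assay, with a stated time of 72 h; on this read-out lower numbers stand for stronger inhibition of growth and higher numbers for weaker inhibition of growth:
compound 1 `CCCC(=O)N1c2ccccc2CCC1C(=O)Nc1cc(C(F)(F)F)cc(C(F)(F)F)c1` gives 15200 nM
compound 2 `O=C(Nc1cc(C(F)(F)F)cc(C(F)(F)F)c1)C1CCc2ccccc2N1C(=O)c1ccc(Cl)cc1` gives 2000 nM
compound 3 `CCC(=O)N1c2ccccc2CCC1C(=O)Nc1cc(C(F)(F)F)cc(C(F)(F)F)c1` gives 7280 nM

Compound 3 stands second highest of the three numbers. Its nearest neighbour is compound 1, with the step of a 2.1-fold lower number from compound 1 to compound 3 (0.32 log units; beyond the scatter); its furthest is compound 2, with the step of a 3.6-fold higher number from compound 2 to compound 3 (0.56 log units; beyond the scatter).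

Compound 4 `O=C(Nc1cc(C(F)(F)F)cc(C(F)(F)F)c1)C1CCc2ccccc2N1C(=O)c1ccccc1` differs from compound 3 by phenyl in place of ethyl on a carbonyl carbon; cut one bond further out, this reads propanoyl to benzoyl. Going by the values given here, two measured steps bear on it. The step of a 3.6-fold higher number from compound 2 to compound 3 (0.56 log units; beyond the scatter) shows what an aryl group in place of an alkyl group on that carbonyl carbon did, and the step of a 7.6-fold lower number from compound 1 to compound 2 (0.88 log units; beyond the scatter) shows the same kind of exchange from the longer chain. Compound 4 carries the aryl group but without the chloro substituent of compound 2, so the step is expected to run in the same direction as these but to fall short of the full size of the step from compound 3 to compound 2. For compound 4 the expected step is a 2.3-fold lower number from compound 3 to compound 4 (0.36 log units; beyond the scatter) in this assay . Compound 4 is therefore estimated at 3200 nM, with a range from 1300 nM to 8000 nM.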

Compound 4, concentration for 50% growth inhibition: 2430 nM
Beside the measured number, compound 4's estimate is 1.3-fold (0.12 log units) above it; the range from low to high includes it.
By their numbers in this assay, from the lowest: compounds 2 and 4 (each within the scatter of the next); then compound 3; then compound 1.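

In this assay, replacing an alkyl chain on the carbonyl carbon with an unsubstituted phenyl gives a step beyond the scatter from either chain length: a 3.0-fold lower number from compound 3 to compound 4 (0.48 log units; beyond the scatter), and a 6.3-fold lower number from compound 1 to compound 4 (0.80 log units; beyond the scatter). The chloro substituent of the 4-chlorophenyl group is not needed to reach this level of growth inhibition, since a 1.2-fold higher number from compound 2 to compound 4 (0.08 log units; within the scatter) lies within the scatter, and this position does not separate hydrogen from chloro on that aromatic carbon. No measurement at hand gives a reason for the difference between the aryl and alkyl acyl groups.

Still open, from the compounds shown here alone, is whether the aromatic ring itself matters at this position, which a cyclohexyl group on the same carbonyl carbon could test, and whether a chain longer than propyl would continue the order seen between the ethyl and propyl compounds. Also open, going by these compounds, is whether any group on the phenyl ring other than chloro, such as methoxy, an amine or a carboxylic acid, or a pyridine ring in place of phenyl, would move the number beyond the scatter.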